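Swapping Piperidine for Bromine on the Shared Core

A few compounds are considered here, and "the series" means these few. Any claim that something is new, unique, unknown or untested is made for them only; others in the source may bear on it.

Among the compounds with values here, compound 1 `N[C@H]1CC[C@H](Nc2c(C(=O)NCc3ccc(F)cc3)nc(N3CCCCC3)c3cccnc23)CC1` is the only member of this small set with a numerical result in a functional assay on HCT-116 cells (Homo sapiens) for cytotoxicity, read by MTT assay, with a stated time of 72 h; a lower number here means a stronger inhibitor, a higher number a weaker inhibitor; in that assay compound 1 gives 8500 nM. Compound 2 `C[C@@H](Nc1c(C(=O)NCc2ccc(F)cc2)nc(Br)c2cccnc12)c1ccccc1` carries bromo where compound 1 carries piperidin-1-yl, together with a different amine. For compound 2 this assay reports only a limit, > 20000 nM. Compound 3 `NCCCNc1c(C(=O)NCc2ccc(F)cc2)ncc2cccnc12` has neither piperidin-1-yl nor bromo and bears a short diamine chain. For compound 3 this assay again reports only a limit, > 10000 nM. Within the data shown here, compound 1 thus stands as the single measured number, the other two results sitting at the limits the limit of > 10000 nM in this assay, at which 1 of the 3 values shown sits, and (the limit of > 20000 nM in this assay, at which 1 of the 3 values shown sits).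

Compound 4 `N[C@H]1CC[C@H](Nc2c(C(=O)NCc3ccc(F)cc3)nc(Br)c3cccnc23)CC1` differs from compound 1 in one place: bromo in place of piperidin-1-yl on an aromatic carbon. Among the measured compounds shown here, no measured pair in this set isolates that change, so its size cannot be read from the data. The limit for compound 2, > 20000 nM, is the nearest pointer for a bromo compound, though its amine differs. Compound 4 is therefore expected to be a weaker inhibitor than compound 1, with an expected step of a 2.1-fold higher number from compound 1 to compound 4 (0.33 log units; beyond the scatter) beyond the scatter, and a result at a limit is a real possibility. The estimate for compound 4 is 18000 nM, with a range from 6000 nM to 50000 nM.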

Compound 4, half-maximal inhibitory concentration: 4000 nM
Beside the measured number, compound 4's estimate is 4.5-fold (0.65 log units) above it; the measured number lies below the stated range.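

Compound 4 shows that the piperidin-1-yl group is not required on this aromatic carbon for cytotoxicity in this assay: replacing it with bromo gives a 2.1-fold lower number from compound 1 to compound 4 (0.33 log units; beyond the scatter), even though the incoming group has 1 heavy atom and the outgoing one has 6 and a ring. With bromo held constant, the group on the nitrogen also matters, since 4-aminocyclohexyl in place of 1-phenylethyl gives an at least 5.0-fold lower number from compound 2 to compound 4 (0.69 log units; beyond the scatter), so bromo alone does not secure the number seen for compound 4. The result for compound 2 is a limit: the limit of > 20000 nM in this assay, at which 1 of the 4 values shown sits.

On these data alone, it remains open whether chloro, morpholine or dimethylamino on this aromatic carbon would give a number like that of compound 4, and so whether the step reflects bromo itself or simply the departure of the piperidin-1-yl ring. It is also open how the bromo compound would respond to a longer diamine chain or a carboxylic acid in place of the 4-aminocyclohexyl group, and the compounds shown do not explain why either step has the size it has.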